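Removing a Chloro Group and What It Does to Solubility

The source may hold more compounds than are shown below. What is called first, only, known or untested is meant among the compounds shown, and "the series" means these compounds.

Measured so far:
compound 1 `O=C(Nc1ccc(F)cc1Cl)c1cc(Cl)ccc1O`, 1.2 ug/mL
compound 2 `O=C(Nc1c(Cl)cc(F)cc1Cl)c1cc(Cl)ccc1O`, > 49 ug/mL
compound 3 `O=C(Nc1ccc(Cl)cc1Cl)c1cc(Cl)ccc1O`, < 1 ug/mL

In a physicochemical assay for solubility (on this read-out lower numbers stand for lower solubility and higher numbers for higher solubility), compound 1 gives 1.2 ug/mL. For compound 2 the value > 49 ug/mL is a limit of the assay, not a number. For compound 3 the value < 1 ug/mL is also a limit. The change hydrogen in place of chloro on an aromatic carbon gave an at least 40-fold lower number from compound 2 to compound 1 (1.61 log units; beyond the scatter), with the limit of > 49 ug/mL in this assay, at which 1 of the 3 values shown sits, at one end. The change an at least 1.2-fold lower number from compound 1 to compound 3 (0.07 log units; that floor lies within the scatter) ends at the limit of < 1 ug/mL in this assay, at which 1 of the 3 values shown sits.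

Compound 4 `O=C(Nc1ccc(Cl)cc1)c1cc(Cl)ccc1O` is not yet measured. It arises by hydrogen in place of chloro on an aromatic carbon, the same kind of change as from compound 2 to compound 1, though here the place is meta to a chloro group only, without the fluoro group. The difference between the cores of compound 3 and compound 2 is not broken down here. Resting on an at least 40-fold lower number from compound 2 to compound 1 (1.61 log units; beyond the scatter), the step that the limit leaves unreadable from compound 3 to compound 4 is expected to run the same way. Compound 4 is estimated at 0.5 ug/mL.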

Compound 4, solubility: < 1 ug/mL
Compound 4: a limit, no number; the forecaster's own chance of this, stated with the estimate: 60%; the middle value lies beyond the limit too.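

Compound 3 and compound 4 each give only a limit of the assay, not a number, so no step between them can be read: the limit of < 1 ug/mL in this assay, at which 2 of the 4 values shown sit.

The compounds shown leave open whether hydrogen in place of this chloro group changes solubility at all.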